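The source may hold more compounds than are shown below. What is called first, only, known or untested is meant among the compounds shown, and "the series" means these compounds.

Of the compounds shown here, two have been measured in a functional assay for antagonist activity at Alpha-1A adrenergic receptor (Oryctolagus cuniculus) (a higher number here means weaker binding, a lower number tighter binding), so far. Compound 1 `COc1ccccc1N1CCN(CCCNc2ccncc2C(=O)N(C)C)CC1` gives 12.6 nM in this assay. Compound 2 `CN(C)C(=O)c1cccnc1NCCCN1CCN(c2ccccc2)CC1` gives 6.31 nM in this assay, which is the lower of the two numbers; compound 1 comes nearest, and the gap between the two lies within the usual scatter of repeated measurements, so the two values are best read as equivalent.

Compound 3 `CCOc1ccccc1N1CCN(CCCNc2ncccc2C(=O)N(C)C)CC1` has not yet been measured in this assay. It differs from compound 2 in one place: ethoxy in place of hydrogen on an aromatic carbon The ethoxy group enters on an aromatic carbon of a six-membered aromatic ring of carbon only, at a position described as ortho to a large group, so that the phenyl of compound 2 becomes a 2-ethoxyphenyl in compound 3.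

Going by the values given here, no step between measured compounds that differ in one place is available to guide the expectation. Since compound 1 and compound 2 sit within the scatter of each other, the expected step of a 1.3-fold higher number from compound 2 to compound 3 (0.10 log units; within the scatter) from compound 2 to compound 3 is small and likely not beyond the scatter, if anything toward a slightly higher number. Compound 3 is therefore estimated at 8 nM in this assay, with a range from 3 nM to 25 nM.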

Compound 3, dissociation constant: 0.501 nM
For compound 3 the middle estimate is 16-fold (1.20 log units) above the measured one, and the stated range ends above it.
By their numbers in this assay, from the lowest: compound 3; then compounds 2 and 1 (each within the scatter of the next).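

The phenyl of compound 2 turns out not to be indifferent to substitution: ethoxy in place of hydrogen on an aromatic carbon, ortho to a large group, gives a 13-fold lower number from compound 2 to compound 3 (1.10 log units; beyond the scatter) in this assay and places compound 3 clearly apart from compound 2. The earlier compounds shown here could not show this, as compound 1 and compound 2 differ in more than one place and their values lie within the scatter of each other, so neither the position nor any group on it could be read from that pair. Nothing shown here explains why the ethoxy group has so large an effect on the number.

As far as these compounds go, what remains open is whether a step of this size is particular to the ethoxy group or would also be seen with other substituents at this position. A single group on a single ring position gives no trend. A hydroxy group, a propoxy chain or a chlorine atom on the same aromatic carbon would separate these readings, and the same ethoxy group on another carbon of the phenyl would show whether the position itself matters.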